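From Ethyl to Difluorophenyl on a Sulfonyl Sulfur

The compounds below may be only part of what the source reports. "The series", "measured", "known", "first", "only" and "open" are said of these compounds alone.

Of the compounds shown here, three sharing one core have been measured in an ADME assay on MT4 cells (Homo sapiens) for cytotoxicity, read by MTT assay, with a stated time of 5 days; on this read-out higher numbers stand for lower toxicity in this test and lower numbers for higher toxicity in this test. Compound 1 `Cc1cc(C)cc(S(=O)(=O)c2c(C(=O)N[C@H]3CCNC3)[nH]c3ccc(Cl)cc23)c1` gives 10000 nM. Compound 2 `Cc1cc(C)cc(S(=O)(=O)c2c(C(=O)NC3CN(Cc4cccnc4)C3)[nH]c3ccc(Cl)cc23)c1` gives 36000 nM, and the difference is a 3.6-fold higher number from compound 1 to compound 2 (0.56 log units; beyond the scatter).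

Compound 3 `CCS(=O)(=O)NC(=O)c1[nH]c2ccc(Cl)cc2c1S(=O)(=O)c1cc(C)cc(C)c1` gives > 283000 nM, which is a limit of the assay and not a number.

Compound 3 still ranks as the least toxic of the three, as the two steps leading to it show: an at least 28-fold higher number from compound 1 to compound 3 (1.45 log units; beyond the scatter) and an at least 7.8-fold higher number from compound 2 to compound 3 (0.89 log units; beyond the scatter).

Compound 4 `Cc1cc(C)cc(S(=O)(=O)c2c(C(=O)NS(=O)(=O)c3ccc(F)cc3F)[nH]c3ccc(Cl)cc23)c1` keeps the sulfonyl on the amide-type nitrogen and differs from compound 3 in one place, with 2,4-difluorophenyl in place of ethyl on a sulfonyl sulfur.

Among the compounds with values here, no measured step changes the group on this sulfur, so the evidence is indirect. Compound 4 retains the ethylsulfonyl-to-sulfonyl link that compound 3 gained in an at least 7.8-fold higher number from compound 2 to compound 3 (0.89 log units; beyond the scatter), which argues against a fall as far as compound 1 at 10000 nM. A new aromatic ring is still a sizeable change, so a modest move to a lower number, meaning somewhat more toxicity, is expected in this assay.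

The expected change is an at least 2.8-fold lower number from compound 3 to compound 4 (0.45 log units; beyond the scatter).

The estimate for compound 4 is 100000 nM, with an expected range from 25000 nM to 300000 nM.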

Compound 4, half-maximal cytotoxic concentration: 121000 nM
For compound 4 the middle estimate is 1.2-fold (0.08 log units) below the measured one, and the stated range covers the measured number.
By their numbers in this assay, from the lowest: compound 1; then compound 2; then compound 4. At a limit, above all of these: compound 3.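

In this assay, within the data shown here, the group on the sulfonyl sulfur proves to matter, and swapping ethyl for 2,4-difluorophenyl gives an at least 2.3-fold lower number from compound 3 to compound 4 (0.36 log units; beyond the scatter) as the only measured change at this position. The sulfonyl link on the amide-type nitrogen is not tied to ethyl, since a 3.4-fold higher number from compound 2 to compound 4 (0.53 log units; beyond the scatter) and a 12-fold higher number from compound 1 to compound 4 (1.08 log units; beyond the scatter) both leave the aromatic sulfonyl compound with the higher number, meaning lower toxicity in this test. The first of these steps gives only a minimum size, because compound 3 stands at a limit of the assay and not at a number: the limit of > 283000 nM in this assay, at which 1 of the 4 values shown sits.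

The compounds shown cannot separate the contribution of the aromatic ring from that of its two fluorine atoms, and a plain phenyl on the same sulfonyl sulfur would pull those two apart. Nor do they show how a longer carbon chain such as butyl, or a phenyl carrying a methoxy group or an amine, would compare at this position.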